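Chloro added to the core of compound 2

This account rests on a few compounds, and the source may have more. Where it says the series, first, only, none or still open, it means among the compounds named here.

Compound 2 `Cc1cc(C)c(CN2CCc3ccc(-c4c(C)noc4C)c(Cl)c3C2=O)c(=O)[nH]1` carries a 3,5-dimethyl-1,2-oxazol-4-yl group on the shared core. In an assay on cells for inhibition of histone-lysine N-methyltransferase EZH2 (Homo sapiens), read by ELISA, with a stated time of 72 h (on this read-out higher numbers stand for weaker inhibition and lower numbers for stronger inhibition), compound 2 gives 105 nM, the lowest of the three numbers at hand. Among the compounds with values here, compound 3 `Cc1cc(C)c(CN2CCc3ccc(OC(C)C)c(Cl)c3C2=O)c(=O)[nH]1` gives 1190 nM in this assay; the single change, isopropoxy in place of 3,5-dimethyl-1,2-oxazol-4-yl on an aromatic carbon, gave an 11-fold higher number from compound 2 to compound 3 (1.05 log units; beyond the scatter). Within the data shown here, compound 1 `Cc1cc(C)c(CN2CCc3c(Cl)cc(-c4cn[nH]c4)c(Cl)c3C2=O)c(=O)[nH]1` gives 1730 nM in this assay; it differs from compound 2 in two places, an added chloro on the core and a different aromatic group, so its two values show only that compound 1 sits markedly higher than compound 2.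

Compound 4 `Cc1cc(C)c(CN2CCc3c(Cl)cc(-c4c(C)noc4C)c(Cl)c3C2=O)c(=O)[nH]1` differs from compound 2 by chloro in place of hydrogen on an aromatic carbon. Among the measured compounds shown here, no measured step isolates this change: the step from compound 2 to compound 3 concerns another carbon, and compound 1 combines the same chloro with a second alteration. The higher number of compound 1 hints at a loss, though not cleanly attributable to the chloro alone. Compound 4 is therefore expected to show a moderate rise, a 3.0-fold higher number from compound 2 to compound 4 (0.48 log units; beyond the scatter). The estimate for compound 4 is 320 nM, with a range from 110 nM to 1200 nM.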

Compound 4, half-maximal inhibitory concentration in the histone-lysine N-methyltransferase EZH2 assay: 15 nM
Estimate against measurement, compound 4: 21-fold (1.33 log units) above, outside the stated range (below it).
By their numbers in the histone-lysine N-methyltransferase EZH2 assay, from the lowest: compound 4; then compound 2; then compounds 3 and 1 (each within the scatter of the next).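

In the histone-lysine N-methyltransferase EZH2 assay this carbon, ortho to a fused ring and para to a chloro group, tolerates chloro and gains from it, in a step beyond the scatter: a 7.0-fold lower number from compound 2 to compound 4 (0.85 log units; beyond the scatter). With the chloro held constant, the aromatic group alone separates the next pair, and in the histone-lysine N-methyltransferase EZH2 assay that change is large: a 120-fold lower number from compound 1 to compound 4 (2.06 log units; beyond the scatter). In a physicochemical assay for lipophilicity, at pH 7.4 (on this read-out higher numbers stand for higher lipophilicity and lower numbers for lower lipophilicity), compound 2 gives 2.6 and compound 4 gives 3.1. In the physicochemical assay the same chloro also comes with higher lipophilicity: the measured distribution coefficient of compound 2, 2.6, and of compound 4, 3.1, a number 0.50 log units higher (beyond the scatter).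

The compounds shown carry only hydrogen or chloro at this carbon, so it remains open whether the gain is particular to chloro; a fluoro, methyl or methoxy group there would test this. Also open, going by these compounds, is whether the chloro gives a similar step alongside 1H-pyrazol-4-yl or isopropoxy, as neither group appears here in a matched pair that differs only by this chloro.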